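The source may hold more compounds than are shown below. What is called first, only, known or untested is meant among the compounds shown, and "the series" means these compounds.

Measured so far:
- compound 1 `COc1ccc(C2=NN(C3=NC(=O)/C(=C4\C(=O)Nc5ccc(Br)cc54)S3)C(c3ccc(OC)cc3)C2)cc1`: 200 nM
- compound 2 `COc1ccc(C2CC(c3ccc4ccccc4c3)=NN2C2=NC(=O)/C(=C3\C(=O)Nc4ccccc43)S2)cc1`: 620 nM

Both compounds were tested in a functional assay on cells (Cancer cell lines, Homo sapiens) for cytotoxicity, read by sulforhodamine B assay, with a stated time of 48 h; a higher number here means a weaker inhibitor of growth, a lower number a stronger inhibitor of growth. Compound 1 gives 200 nM, and compound 2 gives 620 nM. Of the two numbers, compound 2 stands at the higher one, and the gap to compound 1 lies beyond the usual scatter. The two compounds differ in more than one place, so no single structural change can be tied to that gap; the values only show that compound 1 is the stronger grower-inhibitor of the pair.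

Compound 3 `COc1ccc(C2CC(c3ccc4ccccc4c3)=NN2C2=NC(=O)/C(=C3\C(=O)Nc4ccc(Br)cc43)S2)cc1` has not yet been measured. It is derived from compound 2 by one change: bromo in place of hydrogen on an aromatic carbon. For the measured compounds named here, there is no measured step of this exact kind to lean on. Compound 1, which carries a bromo on its own ring system, sits at the lower number, but it also differs from compound 2 elsewhere, so that comparison is only a loose hint. A small step toward a lower number is expected, of a size that may not exceed the scatter, giving a 1.6-fold lower number from compound 2 to compound 3 (0.19 log units; within the scatter). For compound 3 in this assay the estimate is 400 nM, with a plausible range from 150 nM to 1200 nM.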

Compound 3, concentration for 50% growth inhibition: 54 nM
Estimate against measurement, compound 3: 7.4-fold (0.87 log units) above; measured number below the stated range.
By their numbers in this assay, from the lowest: compound 3; then compound 1; then compound 2.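

In this assay, bromo in place of hydrogen on an aromatic carbon, in a six-membered aromatic ring of carbon only that is part of a fused or bridged system of two rings, gives an 11-fold lower number from compound 2 to compound 3 (1.06 log units; beyond the scatter), a large step from a single added atom that the earlier pair, differing in more than one place, could only hint at. With the bromo kept, naphthalen-2-yl in place of 4-methoxyphenyl on a carbon with a double bond to nitrogen gives a 3.7-fold lower number from compound 1 to compound 3 (0.57 log units; beyond the scatter), a modest step, so this second place also bears on growth inhibition in these cells. No measured information shown here explains either step.

The compounds shown leave open whether bromo itself matters or whether another group on the same carbon, such as chloro, methyl or methoxy, would give a similar step. They also leave open whether bromo would give a step of the same size in a compound carrying 4-methoxyphenyl, since only the naphthalen-2-yl series offers a direct comparison with and without it.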